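A few compounds are considered here, and "the series" means these few. Any claim that something is new, unique, unknown or untested is made for them only; others in the source may bear on it.

Working notes on the series.

Compound 1 `CC1=C(C(=O)Nc2ccc(F)cc2)C(c2ccc([N+](=O)[O-])cc2)N=C(SCc2ccccc2)N1` is the reference point; in a functional assay on the whole organism (artery, strain albino) with Rattus norvegicus as the target, with a stated time of 15 min, at a dose of 10 mg/kg by the oral route (on this read-out lower numbers stand for less inhibition and higher numbers for more inhibition at the one dose given (going by the name of the read-out)), compound 1 gives 3.1%. Compound 2 `CC1=C(C(=O)Nc2ccc(F)cc2)C(c2ccc([N+](=O)[O-])cc2)N=C(SCc2cccc(Cl)c2)N1` differs from it by chloro in place of hydrogen on an aromatic carbon, and in this assay compound 2 gives 2.1%; the step of a number 1 percentage points lower from compound 1 to compound 2 (within the scatter) shows no real movement. Compound 3 `CC1=C(C(=O)Nc2ccc(Br)cc2)C(c2ccc(Cl)cc2Cl)N=C(SCc2ccccc2)N1` rests on a different core; the difference between the core of compound 1 and the core of compound 3 is not broken down here. In this assay compound 3 gives 1.5%, which lies within the scatter of both compound 1 and compound 2, so none of the three is set apart from the others and the three numbers read as level at the dose given.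

Compound 4 `CC1=C(C(=O)Nc2ccc(Br)cc2)C(c2ccc(Cl)cc2Cl)N=C(SCc2ccccc2Cl)N1` is not yet measured. It differs from compound 3 by chloro in place of hydrogen on an aromatic carbon. For the measured compounds named here, this is the same kind of change as the one from compound 1 to compound 2, not the same change: there the chlorine enters meta to a large group, here it enters ortho to a large group, on the same kind of six-membered aromatic ring of carbon only.

The expectation for compound 4 rests on the step of a number 1 percentage points lower from compound 1 to compound 2 (within the scatter), which stayed within the scatter, and on the flat, low read-outs of all three measured compounds, in particular compound 3 at 1.5%. The step from compound 3 to compound 4 is therefore expected to be small, a number 1 percentage points higher from compound 3 to compound 4 (within the scatter), and within the scatter. For compound 4 an inhibition of 2.5% is estimated, expected to fall between 0% and 12%.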

Compound 4, a percentage reported as inhibition, in the whole organism at one dose (the size of the read-out at that dose, not a potency): 3.1%
Estimate against measurement, compound 4: 0.6 percentage points below; low and high end bracket the measured number.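

In this assay, chloro in place of hydrogen on an aromatic carbon gives a number 1.6 percentage points higher from compound 3 to compound 4 (within the scatter), so on this second core the change again shows no real movement. Set beside the earlier step, the two cores cannot be told apart in how they take this change: the same change on two cores in this assay, a number 1 percentage points lower (within the scatter) from compound 1 to compound 2 and a number 1.6 percentage points higher (within the scatter) from compound 3 to compound 4, 2.6 percentage points apart, within the scatter of two such steps

This supports only a narrow reading, that the change leaves the read-out level on both cores at the one dose given, with all four compounds low. It does not show that the change would carry over to a compound with a clearly larger read-out, and since the chlorine does not sit in the same place in the two steps, any effect of the core could not be separated from one of place.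

Still open, going by these compounds, is whether a group other than chloro on the ring of the benzyl group, such as an amine or a carboxylic acid, would move the read-out beyond the scatter. Also open is whether a longer chain in place of the benzyl group would do so, and how any of these compounds would read at another dose.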